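From fluoro to nitro on a shared core

A few compounds are considered here, and "the series" means these few. Any claim that something is new, unique, unknown or untested is made for them only; others in the source may bear on it.

Three measured compounds share one core and differ in a single group. In a functional assay on the whole organism (strain albino) with Mus musculus as the target, in the maximal electroshock model, with a stated time of 0.5 h (on this read-out higher numbers stand for an effect only at larger amounts of compound and lower numbers for an effect already at smaller amounts), compound 1 `O=C1c2ccccc2C(=O)N1c1ccccc1` gives 66.2 mg/kg, the chloro compound 2 `O=C1c2ccccc2C(=O)N1c1cccc(Cl)c1` gives 190 mg/kg, and the fluoro compound 3 `O=C1c2ccccc2C(=O)N1c1cccc(F)c1` gives 39.7 mg/kg. Compound 3 stands level with compound 1, as a 1.7-fold lower number from compound 1 to compound 3 (0.22 log units; within the scatter) shows, and well clear of compound 2, as a 4.8-fold lower number from compound 2 to compound 3 (0.68 log units; beyond the scatter) shows.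

Compound 4 `O=C1c2ccccc2C(=O)N1c1cccc([N+](=O)[O-])c1` is still unmeasured. It carries nitro in place of fluoro on an aromatic carbon, meta to a large group (nitro in place of fluoro on an aromatic carbon). For the measured compounds named here, no measured compound holds a nitro group, so the guide is indirect. Going by the values given here, the swaps at this place show that one group can matter, and the only step away from compound 1 beyond the scatter went upward, a 2.9-fold higher number from compound 1 to compound 2 (0.46 log units; beyond the scatter). Among the compounds with values here, compound 3 also sits at the favourable end of the numbers so far. A modest rise is therefore expected, an estimated 2.3-fold higher number from compound 3 to compound 4 (0.36 log units; beyond the scatter). For compound 4 the expected value in this assay is 90 mg/kg, within an estimated range of 30 mg/kg to 260 mg/kg.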

Compound 4, dose for half-maximal effect: 174 mg/kg
For compound 4 the middle estimate is 1.9-fold (0.29 log units) below the measured one; the range from low to high includes it.
By their numbers in this assay, from the lowest: compounds 3 and 1 (each within the scatter of the next); then compounds 4 and 2 (each within the scatter of the next).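

Nitro in place of fluoro gives a 4.4-fold higher number from compound 3 to compound 4 (0.64 log units; beyond the scatter), so compound 3 stands clearly apart at this ring position from a second group as well as from chloro. Nitro in place of hydrogen gives a 2.6-fold higher number from compound 1 to compound 4 (0.42 log units; beyond the scatter), and nitro in place of chloro gives a 1.1-fold lower number from compound 2 to compound 4 (0.04 log units; within the scatter), so in this assay the four compounds form two pairs, compounds 1 and 3 with the lower numbers and compounds 2 and 4 with the higher, and fluoro is the one group here whose step from compound 1 stays within the scatter. No measurement shown explains why chloro and nitro read alike here or why fluoro stays level with hydrogen.

Going by these compounds, whether this split extends to other groups at the same place, such as an amine, a methoxy group or a carboxylic acid, remains open. Also open, on these data alone, is whether fluoro, chloro and nitro would separate in the same way elsewhere on the ring.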